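The source may report more compounds than this note shows. Statements on the series, on what has been measured and on what is new or still open speak of the compounds shown alone.

Compound 1 `CCCOC(=O)Nc1ccc(S(=O)(=O)N2C[C@H](c3ccccc3)NC2=O)cc1CC` gives 60 nM in a functional assay on A549 cells (Homo sapiens) for cytotoxicity, read by MTT assay; a higher number here means a weaker inhibitor, a lower number a stronger inhibitor. Compound 2 `CCc1cc(S(=O)(=O)N2C[C@H](c3ccccc3)NC2=O)ccc1NC(=O)c1ccc(N)cc1` gives 220 nM in this assay, the second highest of the three numbers in hand; compound 3 `CCOC(=O)Nc1ccc(S(=O)(=O)N2C(=O)N[C@@H](c3ccccc3)C2C)cc1Cl` gives 6000 nM in this assay. Going by the values given here, the one single-point step, a 3.7-fold higher number from compound 1 to compound 2 (0.56 log units; beyond the scatter), changes the group on the carbonyl carbon and says nothing about a substituent on the aromatic ring. Compound 4 `CCc1cc(S(=O)(=O)N2C[C@H](c3ccccc3)NC2=O)ccc1NC(=O)c1ccc([N+](=O)[O-])cc1` differs from compound 2 by nitro in place of amino on an aromatic carbon. Among the compounds with values here, no measured step bears on this change, so its direction is unknown and no step beyond the scatter is assumed in this assay. Compound 4 is expected near 250 nM, within 70 nM to 900 nM. The expected step is a 1.1-fold higher number from compound 2 to compound 4 (0.06 log units; within the scatter), a wide guess.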

Compound 4, half-maximal inhibitory concentration: 700 nM
Compound 4: middle estimate off by 2.8-fold (0.45 log units), on the low side; the range from low to high includes it.
By their numbers in this assay, from the lowest: compound 1; then compound 2; then compound 4; then compound 3.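

In this assay, this position para to a large group responds to the substituent: a 3.2-fold higher number from compound 2 to compound 4 (0.50 log units; beyond the scatter) comes with nitro in place of amino. The 4-nitrophenyl group on the carbonyl carbon also gives a 12-fold higher number from compound 1 to compound 4 (1.07 log units; beyond the scatter) against propoxy, so both aryl groups shown give higher numbers than compound 1. No measurement here accounts for the direction of either step.

With only amino and nitro at this position, no trend across substituents can be drawn. On these data alone, a methoxy group, a carboxylic acid or a plain hydrogen there remains open.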